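From Propyl to Hydroxymethyl on the Aromatic Nitrogen

The source may hold more compounds than are shown below. What is called first, only, known or untested is meant among the compounds shown, and "the series" means these compounds.

In a functional assay on HT-29 cells (Homo sapiens) for inhibition, with a stated time of 72 h (on this read-out lower numbers stand for stronger inhibition and higher numbers for weaker inhibition), compound 1 `COc1cc(C(=O)c2ccc3[nH]ccc3c2)cc(OC)c1OC` has a hydrogen on its aromatic nitrogen and stands at 100 nM on this scale. Among the measured compounds shown here, compound 2 `CCCn1ccc2cc(C(=O)c3cc(OC)c(OC)c(OC)c3)ccc21` reads 1800 nM and so holds the higher, weaker of the two numbers so far. Compound 3 `COc1cc(C(=O)c2ccc3c(ccn3CO)c2)cc(OC)c1OC` is still unmeasured and differs from compound 2 by hydroxy in place of ethyl on a saturated chain carbon bound to an aromatic nitrogen in one place. In words, this is hydroxy in place of ethyl on a saturated chain carbon bound to an aromatic nitrogen, which turns propyl into hydroxymethyl. For the measured compounds named here, the only measured step at this nitrogen is an 18-fold higher number from compound 1 to compound 2 (1.26 log units; beyond the scatter) for propyl in place of hydrogen on an aromatic nitrogen, a large move beyond the scatter. Hydroxymethyl is neither of those two groups, and compound 1 at 100 nM marks how far the numbers might fall, so a moderate step toward a lower number is expected in this assay for compound 3, though a single step is thin evidence. The estimated step is a 4.0-fold lower number from compound 2 to compound 3 (0.60 log units; beyond the scatter) in this expectation. The expected value for compound 3 is 450 nM with a range from 120 nM to 1500 nM as its likely span.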

Compound 3, half-maximal inhibitory concentration: 34 nM
Compound 3: the middle estimate sits 13-fold (1.12 log units) above what was measured; the measured number lies below the stated range.
By their numbers in this assay, from the lowest: compound 3; then compound 1; then compound 2.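

Putting a group on the aromatic nitrogen does not have to weaken the compound: in this assay, hydroxymethyl in place of hydrogen gives a 2.9-fold lower number from compound 1 to compound 3 (0.47 log units; beyond the scatter) and so moves the number in the favourable direction. Among the compounds shown here, until now, the only step at this nitrogen was the one for propyl (an 18-fold higher number from compound 1 to compound 2 (1.26 log units; beyond the scatter)), which could have suggested that any group placed here would do harm, but compound 3 goes against that reading. The identity of the group therefore matters, not just its presence, since hydroxy in place of ethyl on the saturated chain carbon bound to the aromatic nitrogen gives a 53-fold lower number from compound 2 to compound 3 (1.72 log units; beyond the scatter), a large change from one small swap that removes two carbons and brings in one oxygen, with one hydrogen-bond donor and one hydrogen-bond acceptor where ethyl had none.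

Nothing measured here explains why these numbers move as they do. From the compounds shown here alone, it also remains open whether the hydroxy group itself is what counts, which a comparison with methyl, methoxymethyl, aminomethyl or the longer hydroxyethyl chain on the same nitrogen could help to settle.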